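A few compounds are considered here, and "the series" means these few. Any claim that something is new, unique, unknown or untested is made for them only; others in the source may bear on it.

Measured in a functional assay on HEp-2 cells (Homo sapiens) for inhibition, read by MTT assay, with a stated time of 72 h; a lower number here means a stronger inhibitor, a higher number a weaker inhibitor:
- compound 1 `O=[N+]([O-])c1ccc(-c2csc(N/N=C/c3ccc(C(F)(F)F)cc3)n2)cc1`: 27300 nM
- compound 2 `O=[N+]([O-])c1cccc(-c2csc(N/N=C/c3ccc(C(F)(F)F)cc3)n2)c1`: 34200 nM

Compound 1 and compound 2 sit within the scatter of each other, so neither ranks ahead of the other.

Compound 3 `FC(F)(F)c1ccc(/C=N/Nc2nc(-c3ccc(Cl)c(Cl)c3)cs2)cc1` keeps the core of compound 1 and carries 3,4-dichlorophenyl in place of 4-nitrophenyl on an aromatic carbon.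

Among the compounds with values here, the one measured step at this place, a 1.3-fold higher number from compound 1 to compound 2 (0.10 log units; within the scatter), only exchanges 4-nitrophenyl for 3-nitrophenyl. Within the data shown here, no measured compound carries 3,4-dichlorophenyl, so the data give no direction for this change. No step beyond the scatter is expected in this assay, though the range is kept wide. The estimated step is a 1.2-fold lower number from compound 1 to compound 3 (0.09 log units; within the scatter). For compound 3 the expected value is 22000 nM, with an estimated range of 8000 nM to 55000 nM.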

Compound 3, half-maximal inhibitory concentration: 10400 nM
For compound 3 the middle estimate is 2.1-fold (0.33 log units) above the measured one; the range from low to high includes it.
By their numbers in this assay, from the lowest: compound 3; then compounds 1 and 2 (each within the scatter of the next).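

In this assay, the aryl group on the aromatic carbon next to the ring nitrogen can move the number beyond the scatter, which the exchange of 4-nitrophenyl for 3-nitrophenyl did not show. Replacing either nitrophenyl with 3,4-dichlorophenyl lowers the number, with a 2.6-fold lower number from compound 1 to compound 3 (0.42 log units; beyond the scatter) and a 3.3-fold lower number from compound 2 to compound 3 (0.52 log units; beyond the scatter), so compound 3 ranks ahead of both nitro compounds, though only modestly. Nothing on hand explains this difference.

The compounds shown do not separate the contributions of the two chlorine positions, so 4-chlorophenyl and 3-chlorophenyl analogues would be the direct test, and an aminophenyl or carboxyphenyl group at this position remains open. The trifluoromethyl-bearing end stays the same throughout, so how this step carries over to other groups there is also unknown.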